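Cyclohexyl to thiophen-3-yl: expectation for compound 4

The source may report more compounds than this note shows. Statements on the series, on what has been measured and on what is new or still open speak of the compounds shown alone.

Going by the values given here, compound 3 `COc1cc(N)c(Cl)cc1NC(=O)C1CCN(CC2CCCCC2)CC1` is the only member with a number in a functional assay on the whole organism for antagonist activity, with Mus musculus as the target (on this read-out higher numbers stand for an effect only at larger amounts of compound and lower numbers for an effect already at smaller amounts), where compound 3 gives 2.9 mg/kg. Compound 1 `COc1cc(N)c(Cl)cc1NC(=O)C1CCN(CC2CCC2)CC1` reaches only a limit, > 10 mg/kg. Compound 2 `COc1cc(N)c(Cl)cc1NC(=O)C1CCN(Cc2ccc(O)cc2)CC1` likewise stops at a limit, > 8 mg/kg. The change to compound 4 `COc1cc(N)c(Cl)cc1NC(=O)C1CCN(Cc2ccsc2)CC1` is thiophen-3-yl in place of cyclohexyl on a saturated chain carbon bound to an amine nitrogen in a ring. Among the compounds with values here, two measured steps bear on it: an at least 3.4-fold lower number from compound 1 to compound 3 (0.53 log units; beyond the scatter) and an at least 2.7-fold lower number from compound 2 to compound 3 (0.44 log units; beyond the scatter). Both run toward cyclohexyl and both give it the lowest number on the saturated chain carbon bound to the amine nitrogen in the ring, so moving away from cyclohexyl to a five-membered aromatic ring is expected to raise the number. For compound 4 the step is expected to be a 2.4-fold higher number from compound 3 to compound 4 (0.38 log units; beyond the scatter). Compound 4 is estimated at 7 mg/kg in this assay, within 2.5 mg/kg to 20 mg/kg.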

Compound 4, dose for half-maximal effect: 3.4 mg/kg
Estimate against measurement, compound 4: 2.1-fold (0.31 log units) above; low and high end bracket the measured number.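

In this assay, the low number at this place is not confined to a saturated ring: a 1.2-fold higher number from compound 3 to compound 4 (0.07 log units; within the scatter) leaves thiophen-3-yl and cyclohexyl indistinguishable, although aromatic compound 2 reaches only a limit. The other steps, an at least 2.3-fold lower number from compound 2 to compound 4 (0.37 log units; beyond the scatter) and an at least 2.9-fold lower number from compound 1 to compound 4 (0.46 log units; beyond the scatter), set compound 4 apart from both limit compounds, and each rests on a limit rather than a number. Nothing shown gives a cause for this result.

Still open, on these data alone, is how thiophen-2-yl, unsubstituted phenyl or a pyridine ring would read at this place. Also open, as far as these compounds go, is whether the limit of compound 2 goes with its hydroxyl group.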